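One More Methoxy on the Aromatic Ring

This account rests on a few compounds, and the source may have more. Where it says the series, first, only, none or still open, it means among the compounds named here.

Of the compounds shown here, three have been tested so far in an ADME assay on BJ cells (Homo sapiens) for cytotoxicity, read by MTT assay, with a stated time of 72 h; on this read-out higher numbers stand for weaker inhibition and lower numbers for stronger inhibition: compound 1 `COc1ccc(CNc2ncnc3c2ncn3C2CCCO2)cc1OC`, compound 2 `COc1ccc(CNc2ncnc3c2ncn3C2CCCO2)c(OC)c1` and compound 3 `COc1ccc(OC)c(CNc2ncnc3c2ncn3C2CCCO2)c1`. Compound 1 gives > 100000 nM, which is a limit of the assay and not a number. Compound 2 gives > 100000 nM, again a limit. Compound 3 gives > 50000 nM, also a limit, so its place on the scale is not pinned to an exact number.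

Compound 4 `COc1cc(OC)c(OC)cc1CNc1ncnc2c1ncn2C1CCCO1` differs from compound 3 by a single change, methoxy in place of hydrogen on an aromatic carbon. Within the data shown here, no two measured compounds differ in just one place, so no measured step serves as a guide. Compound 3 offers only its limit of > 50000 nM as a starting point, and so no change beyond the usual scatter is expected in this assay. The expected move is a step that the limit leaves unreadable from compound 3 to compound 4. For compound 4 the estimated value is 70000 nM, with an expected range from 25000 nM to 200000 nM.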

Compound 4, half-maximal inhibitory concentration: > 100000 nM
Compound 4: no number, only a limit; the forecaster's own chance of this, stated with the estimate: 75%; middle value at least 1.4-fold (0.15 log units) from the limit.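

Among these compounds, no step from compound 1, compound 2 or compound 3 to compound 4 can be read, since all four compounds give only a limit and not a number: the limit of > 100000 nM in this assay, at which 3 of the 4 values shown sit. The compounds shown leave open whether methoxy in place of hydrogen on an aromatic carbon changes the result in this assay at all.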